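A Methyl Added to the Phenoxy Ring of Compound 3

This account rests on a few compounds, and the source may have more. Where it says the series, first, only, none or still open, it means among the compounds named here.

Of the compounds shown here, three have been measured in an assay on HEK293 cells for inhibition of N-acylethanolamine-hydrolyzing acid amidase (Rattus norvegicus), read by LC-MS, with a stated time of 30 min; a lower number here means a stronger inhibitor, a higher number a weaker inhibitor. Compound 1 `O=C(CCCCCc1ccc(F)c(Cl)c1)N1CCOC1=O` gives 26 nM, compound 2 `O=C(CCCCCc1ccc(Br)cc1)N1CCOC1=O` gives 8510 nM, and compound 3 `O=C1OCCN1C(=O)c1ccc(Oc2ccccc2)cc1` gives 680 nM. Compound 3 therefore holds the second highest of the three numbers: compound 2 sits above it, beyond the scatter, and compound 1 lies well below it, also beyond the scatter. Compound 4 `Cc1cccc(Oc2ccc(C(=O)N3CCOC3=O)cc2)c1` differs from compound 3 by methyl in place of hydrogen on an aromatic carbon; in words, methyl in place of hydrogen on an aromatic carbon. Among the measured compounds shown here, no measured pair shows such a change, so no step size can be read from the data. The author expects compound 4 to move little, perhaps slightly downward, with a step of a 1.4-fold lower number from compound 3 to compound 4 (0.13 log units; within the scatter) that may stay within the scatter. Compound 4 is estimated at 500 nM, in a range from 150 nM to 1700 nM.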

Compound 4, half-maximal inhibitory concentration: 5210 nM
Compound 4: middle estimate off by 10-fold (1.02 log units), on the low side; measured number above the stated range.
By their numbers in this assay, from the lowest: compound 1; then compound 3; then compounds 4 and 2 (each within the scatter of the next).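

In this assay, the phenoxy ring of compound 3 does not tolerate this change silently: going from phenyl to 3-methylphenyl adds a single carbon and gives a 7.7-fold higher number from compound 3 to compound 4 (0.88 log units; beyond the scatter), a loss of inhibition beyond the scatter. This is the only single-place step among these compounds, so it is the first direct reading of how this ring responds to a change. The data shown give no explanation for the size of this step.

On these data alone, whether a fluorine or a methoxy group at the same place would give a similar step remains open. So does whether a methyl elsewhere on this ring would behave the same way.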